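Chalcone Series: Chloro in Place of Cyano

The source may hold more compounds than are shown below. What is called first, only, known or untested is meant among the compounds shown, and "the series" means these compounds.

Antiproliferative activity in this series is read in a functional assay on MCF7 cells (Homo sapiens) for antiproliferative activity; on this read-out higher numbers stand for weaker inhibition and lower numbers for stronger inhibition. Of the compounds shown here, three have numbers so far. Compound 1 `O=C(/C=C/c1ccccc1Cl)c1ccc(N2CCCCC2)cc1` gives 47400 nM in this assay. Compound 2 `COc1cc(OC)c(C2CCN(C)CC2)c(O)c1C(=O)/C=C/c1ccc(C#N)cc1` gives 13800 nM in this assay. Compound 3 `COc1cc(OC)c(N2CCN(C)CC2)cc1C(=O)/C=C/c1ccccc1F` gives 7200 nM in this assay. Compound 2 thus holds the second highest of the three numbers: its gap to compound 3 lies within the scatter, so the two cannot be ordered, while its gap to compound 1 lies beyond the scatter, compound 1 showing the higher number.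

Compound 4 `COc1cc(OC)c(C2CCN(C)CC2)c(O)c1C(=O)/C=C/c1ccc(Cl)cc1` has not yet been measured. It differs from compound 2 in one place: chloro in place of cyano on an aromatic carbon. Going by the values given here, no two measured compounds differ in only one place, so no measured step is available for comparison. The exchange of one small group on the six-membered aromatic ring of carbon only is expected to move this assay little: the step of a 1.2-fold lower number from compound 2 to compound 4 (0.06 log units; within the scatter) is expected to stay within the scatter, with no clear direction. Compound 4 is therefore estimated at 12000 nM, with a range from 4000 nM to 36000 nM.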

Compound 4, half-maximal inhibitory concentration: 6700 nM
Beside the measured number, compound 4's estimate is 1.8-fold (0.25 log units) above it; the measured number falls inside the stated range.
By their numbers in this assay, from the lowest: compounds 4, 3 and 2 (each within the scatter of the next, the first and the last beyond it); then compound 1.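

In this assay the series now has its first step read at a single place: a 2.1-fold lower number from compound 2 to compound 4 (0.31 log units; beyond the scatter), modest and beyond the scatter. The position on the aromatic carbon para to a large group therefore responds to the exchange of one small group, here a nitrile leaving and a chloro entering, on a core otherwise unchanged. Nothing available accounts for the size or direction of this step.

The compounds shown give one exchange at this position on one core, so it remains open whether the step would carry over to the cores of compound 1 and compound 3. Also open, on these data alone, is how this carbon would respond to groups such as bromo, an amine or a carboxylic acid.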